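The source may hold more compounds than are shown below. What is called first, only, known or untested is meant among the compounds shown, and "the series" means these compounds.

Measured compounds:
compound 1 `CC#CCn1c(N2CCC[C@@H](N)C2)nc2c1c(=O)n(Cc1ccc(Br)cc1C(=O)OCC)c(=O)n2C` in an ADME assay on isolated protein for inhibition of Dipeptidyl peptidase 9 (Homo sapiens), with stated times of 15 min, 60 s and 20 min (a higher number here means a weaker inhibitor, a lower number a stronger inhibitor), gives > 100000 nM; this value is a limit of the assay and not a number.
compound 2 `CC#CCn1c(N2CCC[C@@H](N)C2)nc2c1c(=O)n(Cc1ccc(Cl)cc1C(=O)OCC)c(=O)n2C` in this assay gives > 100000 nM; this value is likewise a limit of the assay.

Among the measured compounds shown here, compound 2 stands only at a limit, with no numerical reading; the one step measured, a step that the two limits leave unreadable from compound 1 to compound 2, cannot be sized because both ends are limits (the limit of > 100000 nM in this assay, at which 2 of the 2 values shown sit).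

Compound 3 `CC#CCn1c(N2CCC[C@@H](N)C2)nc2c1c(=O)n(Cc1ccc(Cl)cc1C(=O)OC)c(=O)n2C` differs from compound 2 by hydrogen in place of methyl on a saturated chain carbon bound to an oxygen next to a carbonyl group. For the measured compounds named here, no measured step involves the ester chain, so nothing among the measured steps bears directly on this change; the only step known, a step that the two limits leave unreadable from compound 1 to compound 2, concerns a halogen and is unreadable. With compound 2 at the limit, no readable step is expected in this assay, and compound 3 is expected to sit at the limit as well, with a step that the limit leaves unreadable from compound 2 to compound 3.

Estimated value for compound 3 in this assay: 150000 nM, range 40000 nM to 600000 nM.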

Compound 3, half-maximal inhibitory concentration: > 100000 nM
Compound 3 was reported as a limit; the forecaster's own chance of this, stated with the estimate: 85%; the middle value is on the limit's open side.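

In this assay compound 3 gives > 100000 nM, a limit of the assay and not a number, so no new step from compound 1 or compound 2 to compound 3 can be read: the limit of > 100000 nM in this assay, at which 3 of the 3 values shown sit.

The compounds shown leave open whether chloro in place of bromo, or methoxycarbonyl in place of ethoxycarbonyl, has any effect on the reading in this assay.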